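A few compounds are considered here, and "the series" means these few. Any claim that something is new, unique, unknown or untested is made for them only; others in the source may bear on it.

Measured in a toxicity assay on TZM cells (Homo sapiens) for cytotoxicity, read by XTT assay, with a stated time of 3 days; a higher number here means that more compound is tolerated, a lower number that less compound is tolerated:
compound 1 `Cc1ccc(-c2ccc(C(=O)N[C@H](c3nc(C)c(CCO)s3)[C@@H]3CCCCN3)[nH]2)cc1F`, 28800 nM
compound 2 `Cc1ccc(-c2ccc(C(=O)N[C@@H](c3nc(C)c(CCO)s3)[C@@H]3CCCCN3)[nH]2)cc1F`, 15300 nM
compound 3 `Cc1nc([C@@H](NC(=O)c2ccc(-c3ccc(Cl)c(F)c3)[nH]2)[C@@H]2CCCCN2)sc1CCO`, 16100 nM

On these numbers compound 3 sits with compound 2, and its gap to compound 1 is within the scatter, so no order among the three is fixed. Compound 4 `Cc1nc([C@H](NC(=O)c2ccc(-c3ccc(Cl)c(F)c3)[nH]2)[C@@H]2CCCCN2)sc1CCO` is not yet measured. The change from compound 3 to compound 4 is the two compounds have the same atoms and bonds and differ only in configuration as drawn: 1 of 2 stereo elements differ; a stereocentre at a saturated chain carbon is drawn S in compound 3 and R in compound 4. The step that bears on it is a 1.9-fold lower number from compound 1 to compound 2 (0.27 log units; within the scatter), the same change in configuration as drawn, which gave no shift beyond the scatter (the fact that compounds 1 and 2 differ only in the configuration as drawn). The step of a 1.8-fold lower number from compound 1 to compound 3 (0.25 log units; within the scatter) does not concern this change. Nothing beyond the scatter is therefore expected in this assay , with the step from compound 3 to compound 4 estimated as a 1.3-fold lower number from compound 3 to compound 4 (0.13 log units; within the scatter). Compound 4 is expected at 12000 nM, within 5000 nM to 30000 nM.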

Compound 4, half-maximal cytotoxic concentration: 15100 nM
Compound 4: middle estimate off by 1.3-fold (0.10 log units), on the low side; measured number inside the range.
By their numbers in this assay, from the lowest: compounds 4, 2, 3 and 1 (each within the scatter of the next).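

With chloro in place of methyl on the aromatic carbon, the configuration at this saturated chain carbon gives in this assay a 1.1-fold lower number from compound 3 to compound 4 (0.03 log units; within the scatter), so the change stays within the scatter on a second pair: the fact that compounds 3 and 4 differ only in the configuration as drawn. The chloro change can now be read in both configurations, with a 1.0-fold lower number from compound 2 to compound 4 (0.01 log units; within the scatter): the same change on two cores in this assay, a 1.8-fold lower number (0.25 log units; within the scatter) from compound 1 to compound 3 and a 1.0-fold lower number (0.01 log units; within the scatter) from compound 2 to compound 4, 1.8-fold (0.25 log units) apart, within the scatter of two such steps. Across these four compounds, neither change gives a shift beyond the scatter. Open, going by these compounds, is whether a nitrile or a carboxylic acid on that aromatic carbon would shift the number in this assay beyond the scatter. The shown compounds also leave open whether either configuration would matter with such a group.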